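The source may report more compounds than this note shows. Statements on the series, on what has been measured and on what is new or still open speak of the compounds shown alone.

In a functional assay on GBM1 cells (Homo sapiens) for antiproliferative activity, read by WST assay, with a stated time of 72 h (on this read-out higher numbers stand for weaker inhibition and lower numbers for stronger inhibition), compound 1 (`O=C(Nc1cc2ncncc2cc1OCc1ccc(Cl)cc1)Nc1cccc2ccccc12`) gives 7900 nM. That value lies within the scatter of compound 3 (`O=C(Nc1ccc(C(F)(F)F)cc1)Nc1cc2ncncc2cc1OCc1ccccc1`) at 5700 nM, while compound 2 (`O=C(Nc1ccc(C(F)(F)F)cc1)Nc1cc2ncncc2cc1OCc1cccc(Cl)c1`) gives 3400 nM, a lower number than that of compound 1 by a gap that lies beyond the scatter.

Compound 4 (`O=C(Nc1cc2ncncc2cc1OCc1cccc(F)c1)Nc1cccc2ccccc12`) keeps the core of compound 1 and has 3-fluorophenyl in place of 4-chlorophenyl on a saturated chain carbon bound to an oxygen on an aromatic ring.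

Within the data shown here, only one measured step bears on this change, and it does so indirectly. In a 1.7-fold higher number from compound 2 to compound 3 (0.22 log units; within the scatter), hydrogen replaces chloro on an aromatic carbon, and that step stays within the scatter. Among the measured compounds shown here, this pair also differs from compound 1 elsewhere in the structure, and no measured step tests fluoro directly.

No shift beyond the scatter is therefore expected in this assay. The estimated change is small, a 1.2-fold lower number from compound 1 to compound 4 (0.08 log units; within the scatter). For compound 4, the expected value is 6500 nM, with an estimated range from 3000 nM to 14000 nM.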

Compound 4, half-maximal inhibitory concentration: 1300 nM
Compound 4: the middle estimate sits 5.0-fold (0.70 log units) above what was measured; measured number outside the range, below it.
By their numbers in this assay, from the lowest: compound 4; then compounds 2, 3 and 1 (each within the scatter of the next, the first and the last beyond it).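

On the core of compound 1, going from (4-chlorobenzyl)oxy to (3-fluorobenzyl)oxy in this assay gives a 6.1-fold lower number from compound 1 to compound 4 (0.78 log units; beyond the scatter), the first step at this position shown to lie beyond the scatter. Among these compounds, the only earlier step there, a 1.7-fold higher number from compound 2 to compound 3 (0.22 log units; within the scatter), removed a chloro group and stayed within the scatter, so the aromatic ring on this saturated chain carbon is now seen to affect the read-out on at least one core. No evidence at hand explains this shift.

The step changes the halogen and its place on the ring together, so the compounds shown leave open which of the two accounts for it. From the compounds shown here alone, a 4-fluorophenyl group on the core of compound 1 would separate them, and whether the shift carries over to the core of compound 3 also remains open.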